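Trading trifluoromethyl for methoxy on the aromatic ring

A few compounds are considered here, and "the series" means these few. Any claim that something is new, unique, unknown or untested is made for them only; others in the source may bear on it.

In an ADME assay on HEp-2 cells (Homo sapiens) for cytotoxicity (on this read-out higher numbers stand for lower toxicity in this test and lower numbers for higher toxicity in this test), compound 1 `Cc1cccc(NC(=O)[C@@H]2CCCN2S(=O)(=O)c2cccc3cccnc23)c1` gives 25500 nM and compound 2 `Cc1ccc(C(F)(F)F)cc1NC(=O)[C@@H]1CCCN1S(=O)(=O)c1cccc2cccnc12` gives 4800 nM as the lower of the two numbers, which means more toxicity in this test and a gap beyond the usual scatter. Compound 3 `COc1ccc(C)c(NC(=O)[C@@H]2CCCN2S(=O)(=O)c2cccc3cccnc23)c1` has methoxy in place of trifluoromethyl on an aromatic carbon while the rest of compound 2 stays the same. Compound 1 has no trifluoromethyl and stands higher at 25500 nM on this scale, so a moderate rise in this assay beyond the scatter is expected. The expected step is a 2.9-fold higher number from compound 2 to compound 3 (0.46 log units; beyond the scatter) in size. The estimate for compound 3 is 14000 nM with an expected range from 5500 nM to 35000 nM on this read-out.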

Compound 3, half-maximal cytotoxic concentration: 44200 nM
For compound 3 the middle estimate is 3.2-fold (0.50 log units) below the measured one; measured number outside the range, above it.
By their numbers in this assay, from the lowest: compound 2; then compounds 1 and 3 (each within the scatter of the next).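

In this assay, methoxy in place of trifluoromethyl on this aromatic carbon gives a 9.2-fold higher number from compound 2 to compound 3 (0.96 log units; beyond the scatter) here, so this single change is enough to move the number well beyond the scatter. The step of a 1.7-fold higher number from compound 1 to compound 3 (0.24 log units; within the scatter) stays within the scatter, so the 5-methoxy-2-methylphenyl of compound 3 and the 3-methylphenyl of compound 1 cannot be told apart in this test. Nothing available explains why the swap has this effect.

As far as these compounds go, whether a small group such as chlorine or a larger one such as an amine at this place would read like trifluoromethyl or like methoxy remains open.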